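A few compounds are considered here, and "the series" means these few. Any claim that something is new, unique, unknown or untested is made for them only; others in the source may bear on it.

Working notes on the triazine series (the shared core stands in the structures below) in an assay on isolated protein for binding affinity to corticotropin-releasing factor receptor 1 (Homo sapiens); a higher number here means a weaker inhibitor, a lower number a stronger inhibitor.

Compound 1 `CCCN(Cc1ccccc1)c1nc(C)nc(Nc2c(C)cc(C)cc2C)n1` gives 490 nM in this assay. Compound 2 `C=CCN(CC=C)c1nc(C)nc(Nc2c(C)cc(C)cc2C)n1` gives 115 nM in this assay. Of the two numbers, compound 1 stands at the higher one; its nearest neighbour is compound 2, whose number is lower by a margin beyond the usual scatter. Within the data shown here, compound 3 `CCCN(CC1CC1)c1nc(C)nc(Nc2c(CC)cccc2CC)n1` reaches only a limit of this assay, > 10000 nM, and no number; it is the one value of the three that sits at the limit of > 10000 nM in this assay, at which 1 of the 3 values shown sits.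

The step under consideration runs from compound 1 to compound 4 `CCCN(Cc1ccccc1)c1nc(C)nc(Nc2c(C)cccc2C)n1`, which is not yet measured in this assay. The change is hydrogen in place of methyl on an aromatic carbon. Among the measured compounds shown here, no step between two measured compounds reports the effect of that change, so the expectation rests on compound 1 alone and on the general finding that the trimethylphenyl group sits in the better-measured compounds, compounds 1 and 2, while the one compound bearing a 2,6-disubstituted phenyl, compound 3, shows only a limit. The step from compound 1 to compound 4 is expected to be a moderate rise, a 3.1-fold higher number from compound 1 to compound 4 (0.49 log units; beyond the scatter), beyond the scatter. For compound 4 in this assay the expected value is 1500 nM, within a range from 400 nM to 6000 nM.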

Compound 4, inhibition constant: > 10000 nM
Compound 4: a limit, no number; the forecaster's own chance of this, stated with the estimate: 10%; middle value at least 6.6-fold (0.82 log units) from the limit.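

In this assay, the change from 2,4,6-trimethylphenyl to 2,6-dimethylphenyl gives an at least 20-fold higher number from compound 1 to compound 4 (1.30 log units; beyond the scatter), a large step beyond the scatter. Among these compounds, this is the first direct reading for the methyl that sits para to a large group and meta to two methyl groups: with the rest of compound 1 held fixed, this single methyl separates a measured number from a limit. Compound 4 stands at a limit of the assay, > 10000 nM, and not at a number, so the step gives only a lower bound, and compound 4 is the second compound of the series at that limit: the limit of > 10000 nM in this assay, at which 2 of the 4 values shown sit.

The compounds shown leave open whether the methyl is specifically needed at this place or whether another group there, such as a methoxy group, a chlorine atom or an ethyl group, would keep a measurable number like that of compound 1, 490 nM. They also leave open whether the same change on compound 2 would give a step of similar size.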